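The compounds below may be only part of what the source reports. "The series", "measured", "known", "first", "only" and "open" are said of these compounds alone.

Measured in a functional assay on the whole organism for activation, with Mus musculus as the target; a higher number here means that more compound is needed for the effect, a lower number that less compound is needed:
compound 1 `CCCCCOc1nc(N)c2nc(O)n(Cc3ccccc3)c2n1` — 0.3 mg/kg
compound 2 `CSc1nc(N)c2nc(O)n(Cc3ccccc3)c2n1` — 0.1 mg/kg
compound 3 `CCCNc1nc(N)c2nc(O)n(Cc3ccccc3)c2n1` — 1 mg/kg

Compound 3 stands at the highest number of the three; its nearest neighbour is compound 1 and the furthest is compound 2, both lying beyond the scatter from it. Compound 4 `CCCSc1nc(N)c2nc(O)n(Cc3ccccc3)c2n1` differs from compound 3 in one place: propylsulfanyl in place of propylamino on an aromatic carbon. Among the compounds with values here, the step that bears on this is a 10-fold higher number from compound 2 to compound 3 (1.00 log units; beyond the scatter), which runs the opposite way and is the largest step in the set; the chain in compound 4 is longer than in compound 2, and no step in this assay isolates chain length on a sulfanyl group, so the size of the return is uncertain. A step down, beyond the scatter, is expected: a 5.0-fold lower number from compound 3 to compound 4 (0.70 log units; beyond the scatter). Compound 4 is therefore estimated at 0.2 mg/kg (range 0.07 mg/kg to 0.6 mg/kg).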

Compound 4, minimum effective dose: 0.1 mg/kg
For compound 4 the middle estimate is 2.0-fold (0.30 log units) above the measured one; measured number inside the range.
By their numbers in this assay, from the lowest: compounds 2 and 4 (each within the scatter of the next); then compound 1; then compound 3.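

In this assay, propylsulfanyl in place of propylamino, with the heavy-atom count unchanged, gives a 10-fold lower number from compound 3 to compound 4 (1.00 log units; beyond the scatter) and shows that this position responds to the exchange of nitrogen for sulfur in the link at fixed chain length. Extending the sulfur chain gives no change at the digits printed from compound 2 to compound 4 (within the scatter) and so leaves the number unmoved across methylsulfanyl and propylsulfanyl, while a 3.0-fold lower number from compound 1 to compound 4 (0.48 log units; beyond the scatter) shows propylsulfanyl also differing from pentyloxy. Nothing available here accounts for these steps.

Open, going by these compounds, are longer sulfanyl chains such as pentylsulfanyl, which would pair directly with pentyloxy, and the shorter methoxy and methylamino groups, which would complete the comparison of links at the methyl chain.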